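From furan-2-yl to ethynyl on a shared core

This account rests on a few compounds, and the source may have more. Where it says the series, first, only, none or still open, it means among the compounds named here.

Of the compounds shown here, three on a shared core have been tested in a functional assay on CEM-DNR-bulk cells (Homo sapiens), read by MTT assay, with a stated time of 72 h (a higher number here means a weaker inhibitor, a lower number a stronger inhibitor), and only one returned a number. Compound 1 `COc1ncnc2c1c(-c1cc3ccccc3o1)cn2[C@@H]1O[C@H](CO)[C@@H](O)[C@H]1O` gives 10800 nM as a measured value. Compound 2 `CSc1ncnc2c1c(-c1ccccc1)cn2[C@@H]1O[C@H](CO)[C@@H](O)[C@H]1O` shows > 20000 nM as a limit of the assay and not a number. Compound 3 `CNc1ncnc2c1c(-c1ccco1)cn2[C@@H]1O[C@H](CO)[C@@H](O)[C@H]1O` shows > 20000 nM as a limit too. Compound 3 thus stands at the limit of > 20000 nM in this assay, at which 2 of the 3 values shown sit, without a number of its own.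

Compound 4 `C#Cc1cn([C@@H]2O[C@H](CO)[C@@H](O)[C@H]2O)c2ncnc(NC)c12` awaits measurement. Its difference from compound 3 is ethynyl in place of furan-2-yl on an aromatic carbon in a single place, with ethynyl in place of furan-2-yl on an aromatic carbon of a five-membered aromatic ring with 1 nitrogen.

For the measured compounds named here, no measured pair shows this change alone, so the size of the step remains open. Compound 1 at 10800 nM shows that a number can be reached on this core in this assay and this is the only ground for expecting some strengthening. The expected step of an at least 2.5-fold lower number from compound 3 to compound 4 (0.39 log units; beyond the scatter) is an estimate towards stronger inhibition, and a reading that again gives only a limit remains quite possible. For compound 4 the estimated value is 8000 nM with an expected range of 700 nM to 30000 nM in this measurement.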

Compound 4, half-maximal inhibitory concentration: 18500 nM
For compound 4 the middle estimate is 2.3-fold (0.36 log units) below the measured one; the range from low to high includes it.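

In this assay, for the compounds shown here, the change to ethynyl on this aromatic carbon, two ring bonds from the ring nitrogen, gives the first single-place comparison on the shared core, and it shows that a measured number can be reached with methylamino kept in place: the step is an at least 1.0-fold lower number from compound 3 to compound 4 (0.03 log units; that floor lies within the scatter). It also shows that a ring is not needed on this carbon for a number to appear, since ethynyl brings 2 heavy atoms and no ring where furan-2-yl brought 5 heavy atoms and a five-membered aromatic ring. Compound 3 gives > 20000 nM, which is a limit of the assay and not a number, so the step has only a floor and its true size stays unknown because the reading sits at a limit shared with another compound: the limit of > 20000 nM in this assay, at which 2 of the 4 values shown sit.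

What the compounds shown leave open is how far the number moves with other groups on this carbon, such as a longer chain ending in an amine or a carboxylic acid. They also cannot tell whether ethynyl would give a similar reading with methoxy or methylsulfanyl on the shared core in place of the methylamino group.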